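Swapping a pyridin-2-yl for a methyl-oxadiazolyl on the pyrrolidinone

The compounds below may be only part of what the source reports. "The series", "measured", "known", "first", "only" and "open" are said of these compounds alone.

Values measured in a toxicity assay on HepG2 2.2.15 cells (Homo sapiens) for cytotoxicity, read by CellTiter-Glo; on this read-out higher numbers stand for lower toxicity in this test and lower numbers for higher toxicity in this test:
compound 1 `O=C1CC(c2ccccn2)CN1c1cnn2c1CN(C(=O)Nc1cc(F)c(F)c(F)c1)C(C1CC1)C2` gives 96200 nM
compound 2 `C[C@H]1Cn2ncc(N3CC(c4ccccc4)CC3=O)c2CN1C(=O)Nc1cc(F)c(F)c(F)c1` gives 12800 nM
compound 3 `CC1(C)CN(C(=O)Nc2cc(F)c(F)c(F)c2)Cc2c(N3CC(C#N)CC3=O)cnn21` gives > 200000 nM

Among the two numbers available in this assay, compound 1 stands highest; compound 2 sits a good way lower, and that gap lies beyond the usual scatter. For compound 3 the result is only a limit of the assay, not a number, as the limit of > 200000 nM in this assay, at which 1 of the 3 values shown sits, records.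

Compound 4 `Cc1nc(C2CC(=O)N(c3cnn4c3CN(C(=O)Nc3cc(F)c(F)c(F)c3)C(C3CC3)C4)C2)no1` is the compound not yet measured. It differs from compound 1 in one place: 5-methyl-1,2,4-oxadiazol-3-yl in place of pyridin-2-yl on a saturated ring carbon. Among the compounds with values here, no pair of measured compounds here differs by the same change, so there is no measured step to lean on. The two groups are of the same size and the change is at the far end of the molecule from the urea. The expected step in this assay is therefore small, towards a somewhat higher number, if anything, and possibly none beyond the scatter. Compound 4 is estimated at 120000 nM, between 50000 nM and 250000 nM, which corresponds to an expected step of a 1.2-fold higher number from compound 1 to compound 4 (0.10 log units; within the scatter).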

Compound 4, half-maximal cytotoxic concentration: > 200000 nM
Compound 4 was reported as a limit; the forecaster's own chance of this, stated with the estimate: 30%; at least 1.6-fold (0.22 log units) between middle value and limit.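

The pyridin-2-yl on this saturated ring carbon of the five-membered non-aromatic ring is not a neutral substituent in this assay: replacing it with 5-methyl-1,2,4-oxadiazol-3-yl gives an at least 2.0-fold higher number from compound 1 to compound 4 (0.31 log units; beyond the scatter). This is the only step shown at this position, and the earlier compounds, which differ from one another in more than one place, could not show that a change here alone moves the read-out beyond the scatter. Compound 4 is reported only as a limit, not as a number: the limit of > 200000 nM in this assay, at which 2 of the 4 values shown sit.

The compounds shown leave open whether other groups on the same carbon, such as a primary amine, a carboxylic acid or a plain methyl, would shift the read-out in the same way. They also leave open whether the step would hold if the cyclopropyl group on the core were replaced by a hydrogen.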